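Amide substituent series: from diol to diacid

The source may report more compounds than this note shows. Statements on the series, on what has been measured and on what is new or still open speak of the compounds shown alone.

Compound 1 `CCN(CC)CCNC(=O)c1ccc(C(CC)(CC)c2ccc(OCS(=O)(=O)c3ccccc3)c(C)c2)n1CC` is the reference point of this set; in a functional assay on BXPC-3 cells (Homo sapiens) for antiproliferative activity, read by MTT assay, with a stated time of 24 h (a lower number here means a stronger inhibitor, a higher number a weaker inhibitor), compound 1 gives 6270 nM. Compound 2 `CCn1c(C(=O)NCCO)ccc1C(CC)(CC)c1ccc(OCS(=O)(=O)c2ccccc2)c(C)c1` carries a hydroxy in place of diethylamino on a saturated chain carbon, two bonds along the chain from an amide-type nitrogen, and in this assay compound 2 gives 19900 nM, the step being a 3.2-fold higher number from compound 1 to compound 2 (0.50 log units; beyond the scatter). Compound 3 `CCn1c(C(=O)N[C@H](CO)CCCO)ccc1C(CC)(CC)c1ccc(OCS(=O)(=O)c2ccccc2)c(C)c1` goes further along the same line. In this assay compound 3 reaches only a limit of the assay, > 50000 nM, so no number is known for it. Compound 3 thus stands at the limit of > 50000 nM in this assay, at which 1 of the 3 values shown sits. The steps of an at least 7.9-fold higher number from compound 1 to compound 3 (0.90 log units; beyond the scatter) and an at least 2.5-fold higher number from compound 2 to compound 3 (0.40 log units; beyond the scatter) both run toward weaker inhibition as the group on the amide-type nitrogen is changed.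

Compound 4 `CCn1c(C(=O)N[C@H](CC(=O)O)C(=O)O)ccc1C(CC)(CC)c1ccc(OCS(=O)(=O)c2ccccc2)c(C)c1` takes the next step: a group of 8 heavy atoms (4 carbon, 4 oxygen; no ring) in place of a group of 7 heavy atoms (5 carbon, 2 oxygen; no ring), on an amide-type nitrogen. The three measured steps all bear on this position and all point the same way, each beyond the scatter, with compound 3 already at the limit. Among the compounds with values here, no step within this set runs toward stronger inhibition at this position. Compound 4 is therefore expected to sit at or past that limit, a step that the limit leaves unreadable from compound 3 to compound 4. For compound 4 the estimated value in this assay is 70000 nM, within a range from 25000 nM to 250000 nM.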

Compound 4, half-maximal inhibitory concentration: > 50000 nM
Compound 4: no number, only a limit; the forecaster's own chance of this, stated with the estimate: 85%; the middle value does not contradict the limit.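

In this assay compound 4 gives > 50000 nM, which is a limit of the assay and not a number. What is new is that a group carrying two carboxylic acids, 1,2-dicarboxyethyl, brings no measurable return of activity on this amide-type nitrogen: an at least 2.5-fold higher number from compound 2 to compound 4 (0.40 log units; beyond the scatter) and an at least 7.9-fold higher number from compound 1 to compound 4 (0.90 log units; beyond the scatter) run the same way as the steps to compound 3, while the step between compound 3 and compound 4 cannot be read. Two different groups on this nitrogen, one with hydroxy groups and one with carboxylic acids, now end at the same limit, so the assay no longer separates them: the limit of > 50000 nM in this assay, at which 2 of the 4 values shown sit.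

From the compounds shown here alone, the order of compound 3 and compound 4 stays unknown, as does whether a single carboxylic acid in place of the hydroxy of compound 2 would give a readable number. Also open, going by these compounds, is whether a longer chain ending in diethylamino, or a primary amine on the 2-carbon chain, would give a lower number than compound 1 gives, 6270 nM.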